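Cyclohexyl Ester Variant: Expected Cytotoxicity on Cells

The source may hold more compounds than are shown below. What is called first, only, known or untested is meant among the compounds shown, and "the series" means these compounds.

Compound 1, `CCCCCCCCOC(=O)C(O)Cn1cnc2c(N)ncnc21`: 100 ug/mL
Compound 2, `COCCOC(=O)C(O)Cn1cnc2c(N)ncnc21`: > 400 ug/mL
Compound 3, `COC(=O)C(O)Cn1cnc2c(N)ncnc21`: > 400 ug/mL

All three compounds share one core and differ only in the ester group, and all were tested in a functional assay on HeLa cells (Homo sapiens) for cytotoxicity; on this read-out higher numbers stand for lower toxicity in this test and lower numbers for higher toxicity in this test. Compound 1 gives 100 ug/mL. For compound 2 the value > 400 ug/mL is a limit of the assay, not a number. For compound 3 the value > 400 ug/mL is likewise a limit of the assay. Compound 3 therefore stands at the top of this set, where (the limit of > 400 ug/mL in this assay, at which 2 of the 3 values shown sit); nothing finer than that can be said of it.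

Compound 4, `Nc1ncnc2c1ncn2CC(O)C(=O)OC1CCCCC1`, has not yet been measured. It differs from compound 3 in one place: cyclohexyl in place of methyl on an oxygen next to a carbonyl group. Among the compounds with values here, the steps that bear on this are an at least 4.0-fold higher number from compound 1 to compound 3 (0.60 log units; beyond the scatter) and an at least 4.0-fold higher number from compound 1 to compound 2 (0.60 log units; beyond the scatter): shortening the ester chain moved the read-out from a number up to the limit. Putting cyclohexyl in place of methyl goes part of the way back toward compound 1, so a lower number than the limit is expected, though of uncertain size. Compound 4 is thus expected to give about 200 ug/mL, likely between 50 ug/mL and 400 ug/mL. This expected change corresponds to an at least 2.0-fold lower number from compound 3 to compound 4 (0.30 log units; that floor lies within the scatter).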

Compound 4, minimum cytotoxic concentration: 100 ug/mL
Compound 4: the middle estimate sits 2.0-fold (0.30 log units) above what was measured; the range from low to high includes it.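

In this assay, cyclohexyl on the ester oxygen brings the read-out down from the assay's limit to a real number, giving an at least 4.0-fold lower number from compound 3 to compound 4 (0.60 log units; beyond the scatter) and also an at least 4.0-fold lower number from compound 2 to compound 4 (0.60 log units; beyond the scatter). Until now, only the octyl ester of compound 1 had given a number rather than a limit, so a straight chain is evidently not required: a six-membered ring of carbon only serves as well. Comparing the two groups directly gives no change at the digits printed from compound 1 to compound 4 (within the scatter), so in this assay the ring and the octyl chain cannot be told apart.

From the compounds shown here alone, whether a butyl chain or a small ring such as cyclopropyl would already leave the limit remains open. So does the effect of a phenyl ring, or of a piperidine ring with its nitrogen, on the ester oxygen.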